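This account rests on a few compounds, and the source may have more. Where it says the series, first, only, none or still open, it means among the compounds named here.

Measured in a functional assay on A549 cells (Homo sapiens) for inhibition; on this read-out higher numbers stand for weaker inhibition and lower numbers for stronger inhibition:
- Compound 1 `COc1cc(/C=C/c2cn(C(C)=O)c3ccccc23)cc(OC)c1OC`: > 5000 nM, a limit and not a number
- Compound 2 `COc1cc(/C=C/c2c[nH]c3ccccc23)cc(OC)c1OC`: 3230 nM
- Compound 3 `COc1cc(/C=C\c2c[nH]c3ccccc23)cc(OC)c1OC`: 3230 nM

Compound 2 stands level with compound 3 on these numbers. Reversing the drawn double bond gives no change at the digits printed from compound 2 to compound 3 (within the scatter). Compound 4 `COc1cc(/C=C/c2cn(C)c3ccccc23)cc(OC)c1OC` keeps the double bond of compound 2 and carries methyl in place of hydrogen on an aromatic nitrogen, methyl in place of hydrogen on an aromatic nitrogen. Within the data shown here, the one measured step at that nitrogen is an at least 1.5-fold lower number from compound 1 to compound 2 (0.18 log units; that floor lies within the scatter). Compound 1 sits at the limit of > 5000 nM in this assay, at which 1 of the 3 values shown sits, so that step offers only a floor. No step beyond the scatter is therefore expected in this assay, and neither direction is favoured. The expected change is a 1.1-fold higher number from compound 2 to compound 4 (0.03 log units; within the scatter). Compound 4 is estimated at 3500 nM, with an expected range of 1200 nM to 8000 nM.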

Compound 4, half-maximal inhibitory concentration: 3090 nM
Compound 4: the middle estimate sits 1.1-fold (0.05 log units) above what was measured; the measured number falls inside the stated range.
By their numbers in this assay, from the lowest: compounds 4, 2 and 3 (each within the scatter of the next). At a limit, above all of these: compound 1.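

In this assay, the change on the aromatic nitrogen gives a 1.0-fold lower number from compound 2 to compound 4 (0.02 log units; within the scatter), so replacing hydrogen with methyl at this position produces no step beyond the scatter. Compound 1 stands at > 5000 nM, which is a limit and not a number. Replacing acetyl with methyl gives an at least 1.6-fold lower number from compound 1 to compound 4 (0.20 log units; that floor lies within the scatter), and this comparison offers only a floor: the limit of > 5000 nM in this assay, at which 1 of the 4 values shown sits.

The compounds shown leave open whether a longer chain at this nitrogen, such as propyl, or a chain ending in an amine or a carboxylic acid, would move the number beyond the scatter.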